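Propyl for isopropyl on the acyl group of compound 1

The compounds below may be only part of what the source reports. "The series", "measured", "known", "first", "only" and "open" are said of these compounds alone.

Compound 1 `CCCCCCCCO[C@@H]1O[C@@H](C)[C@H](OC(=O)CCCCC)[C@@H](O[C@@H]2O[C@@H](C)[C@H](OC(C)=O)[C@@H](OC(=O)C(C)C)[C@H]2OC(C)=O)[C@H]1O` is measured in a functional assay on NCI-H460 cells (Homo sapiens) for antiproliferative activity, read by MTT assay, with a stated time of 48 h (a lower number here means a stronger inhibitor, a higher number a weaker inhibitor), and gives 47000 nM. Among the three numbers measured it holds the second highest. Compound 3 `CCCCCCCCCCCCO[C@@H]1O[C@@H](C)[C@H](O[C@@H]2O[C@@H](C)[C@H](OC(C)=O)[C@@H](O[C@@H]3O[C@@H](C)[C@H](OC(C)=O)[C@@H](O)[C@H]3OC(C)=O)[C@H]2O)[C@@H](O)[C@H]1O` gives 91000 nM, which lies within the scatter of compound 1, so no order between these two is read. Compound 2 `CCCCCCCCO[C@@H]1O[C@@H](C)[C@H](OC(=O)CCCCC)[C@@H](O[C@@H]2O[C@@H](C)[C@H](OC(C)=O)[C@@H](O[C@@H]3O[C@@H](C)[C@H](OC(C)=O)[C@@H](O)[C@H]3O)[C@H]2OC(C)=O)[C@H]1O` gives 9000 nM, the lowest of the three and beyond the scatter from compound 1. Among the measured compounds shown here, no pair of the measured compounds differs in a single place, so no single-point step is available to lean on.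

Compound 4 `CCCCCCCCO[C@@H]1O[C@@H](C)[C@H](OC(=O)CCCCC)[C@@H](O[C@@H]2O[C@@H](C)[C@H](OC(C)=O)[C@@H](OC(=O)CCC)[C@H]2OC(C)=O)[C@H]1O` is not yet measured. It differs from compound 1 by propyl in place of isopropyl on a carbonyl carbon; the same atoms are joined differently, reading as isopropylcarbonyl to propylcarbonyl. For the measured compounds named here, no measured step of this kind exists among the three compounds. The step of a 1.0-fold lower number from compound 1 to compound 4 (0.02 log units; within the scatter) is expected to stay within the scatter, with no direction claimed. Compound 4 is estimated at 45000 nM, with a range from 20000 nM to 100000 nM.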

Compound 4, half-maximal inhibitory concentration: 32000 nM
Compound 4: the middle estimate sits 1.4-fold (0.15 log units) above what was measured, and the stated range covers the measured number.
By their numbers in this assay, from the lowest: compound 2; then compounds 4, 1 and 3 (each within the scatter of the next, the first and the last beyond it).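

In this assay, among the compounds shown here, propyl in place of isopropyl on this carbonyl carbon gives a 1.5-fold lower number from compound 1 to compound 4 (0.17 log units; within the scatter), the first step between compounds that differ in one place. At this position, the two arrangements of the same carbons cannot be told apart, so no preference between propyl and isopropyl is read. No measurement bears on why the step is this size, and the reading rests on the two numbers alone.

Still open, from the compounds shown here alone, is whether a larger change on this carbonyl carbon, such as a longer chain, a phenyl ring or a carboxylic acid, would carry the number beyond the scatter. Also open, going by these compounds, is whether propyl and isopropyl would stay equally close on a different core, such as that of compound 2.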